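A few compounds are considered here, and "the series" means these few. Any claim that something is new, unique, unknown or untested is made for them only; others in the source may bear on it.

Measured compounds:
- compound 1, `CC(C)(C)c1cc(C(=O)NC2CCN(Cc3ccccc3)CC2)cc(C(C)(C)C)c1O`, giving 85100 nM in an assay on isolated protein for inhibition of Amine oxidase [flavin-containing] B (Homo sapiens), read by fluorescence, with stated times of 15 min and 20 min; on this read-out lower numbers stand for stronger inhibition and higher numbers for weaker inhibition
- compound 2, `CC(C)(C)c1cc(CCC(=O)NCCC2CCN(Cc3ccccc3)CC2)cc(C(C)(C)C)c1O`, giving 46900 nM in this assay
- compound 3, `CC(C)(C)c1cc(/C=C/C(=O)NCCC2CCN(Cc3ccccc3F)CC2)cc(C(C)(C)C)c1O`, giving 7400 nM in this assay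

Compound 3 stands lowest of the three numbers in this assay. Its nearest neighbour is compound 2, whose number is higher by a margin beyond the scatter, and compound 1 lies further still, also beyond the scatter. Compound 3 is therefore the strongest inhibitor among the measured set.

Compound 4, `CC(C)(C)c1cc(/C=C/C(=O)NCCC2CCN(Cc3ccc(Br)cc3)CC2)cc(C(C)(C)C)c1O`, differs from compound 3 in a single place: 4-bromophenyl in place of 2-fluorophenyl on a saturated chain carbon bound to an amine nitrogen in a ring. Among the compounds with values here, no measured pair in this set shows this kind of halogen swap on the benzyl group, so there is no measured step to lean on. Given that the rest of the structure is unchanged, the step from compound 3 to compound 4 in this assay is expected to be small, most likely none beyond the scatter, as a 1.2-fold lower number from compound 3 to compound 4 (0.09 log units; within the scatter) expresses. The expected value for compound 4 in this assay is 6000 nM, within a range from 2500 nM to 15000 nM.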

Compound 4, half-maximal inhibitory concentration: 13200 nM
Compound 4: the middle estimate sits 2.2-fold (0.34 log units) below what was measured; low and high end bracket the measured number.
By their numbers in this assay, from the lowest: compounds 3 and 4 (each within the scatter of the next); then compounds 2 and 1 (each within the scatter of the next).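

Within the data shown here, the pair gives the first single-place step in this set: in this assay the change from 2-fluorobenzyl to 4-bromobenzyl reads as a 1.8-fold higher number from compound 3 to compound 4 (0.25 log units; within the scatter) and so gives no measurable difference. On a saturated chain carbon bound to an amine nitrogen in a ring, then, 4-bromophenyl and 2-fluorophenyl cannot be told apart by this read-out. Nothing measured alongside these numbers bears on what lies behind this result.

The halogen and its place on the ring change together in this one step, so the pair cannot separate the two, and 2-bromobenzyl or 4-fluorobenzyl groups on the core of compound 3 would be needed to do so. As far as these compounds go, how a 4-methoxybenzyl or a pyridylmethyl group would read at this position also remains open.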